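Methoxyethylamino for piperidinyl on the fused pyridine-type core

The source may report more compounds than this note shows. Statements on the series, on what has been measured and on what is new or still open speak of the compounds shown alone.

Measured so far:
- compound 1 `Nc1n[nH]c2cc(-c3ccncc3)[nH]c(=O)c12`: 4%
- compound 2 `Cc1cc2[nH]nc(N)c2c(N2CCCCC2)n1`: 11%
- compound 3 `Cc1cc2c(c(N)nn2C)c(N2CCCCC2)n1`: 0%

All three numbers come from an assay on isolated protein for inhibition of RAC-beta serine/threonine-protein kinase (Homo sapiens), read by mobility shift assay, tested at 30 uM; on this read-out higher numbers stand for more inhibition at the one concentration tested (going by the name of the read-out) and lower numbers for less inhibition. Compound 3 stands lowest of the three; its gap to compound 1 is within the scatter, its gap to compound 2 is beyond it. Among the compounds with values here, the one step between neighbours, a number 11 percentage points lower from compound 2 to compound 3 (beyond the scatter), concerns methyl in place of hydrogen on an aromatic nitrogen and does not touch the position changed next.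

Compound 4 `COCCNc1nc(C)cc2c1c(N)nn2C` differs from compound 3 by (2-methoxyethyl)amino in place of piperidin-1-yl on an aromatic carbon. Within the data shown here, no measured pair changes this group, so nothing bears directly on the step. The series as a whole sits at low inhibition in this assay, and the step of a number 4 percentage points higher from compound 3 to compound 4 (within the scatter) is expected to stay within the scatter. Compound 4 is therefore estimated at 4%, with a range from -8% to 16%, because compound 3 gives 0% and the change is not covered by any measured step.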

Compound 4, a percentage reported as inhibition, at one concentration (the size of the read-out at that concentration, not a potency): -3%
Beside the measured number, compound 4's estimate is 7 percentage points above it; measured number inside the range.
By their numbers in this assay, from the lowest: compounds 4, 3, 1 and 2 (each within the scatter of the next, the first and the last beyond it).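

Within the data shown here, measured in this assay the exchange of piperidin-1-yl for (2-methoxyethyl)amino on this aromatic carbon gives a number 3 percentage points lower from compound 3 to compound 4 (within the scatter) and is the first read on this position: a chain with no ring can replace the six-membered non-aromatic ring without moving the number beyond the scatter. Both compounds carry the methyl on the aromatic nitrogen, and with compound 3 at 0% and compound 4 at -3% the pair sits at the low end of the series, where this change shows neither gain nor loss. Nothing available explains the result.

On these data alone, whether the same exchange behaves alike with hydrogen on the aromatic nitrogen, as in compound 2 at 11%, stays open. Also open, as far as these compounds go, is whether a morpholine ring, a longer ether chain or a carboxylic acid on this aromatic carbon would lift inhibition clear of the scatter.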